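Swapping chloro for bromo on the phenyl ring

The source may hold more compounds than are shown below. What is called first, only, known or untested is meant among the compounds shown, and "the series" means these compounds.

- compound 1 `Cc1cc2occ(-c3nc(-c4ccccc4)c(-c4ccccc4)n3-c3ccc(Cl)c(Cl)c3)c(=O)c2cc1Cl` gives 12500 nM
- compound 2 `Cc1cc2occ(-c3nc(-c4ccccc4)c(-c4ccccc4)n3-c3ccc(Cl)cc3)c(=O)c2cc1Cl` gives 1560 nM
- compound 3 `Cc1cc2occ(-c3nc(-c4ccccc4)c(-c4ccccc4)n3-c3ccc(Br)cc3)c(=O)c2cc1Cl` is not yet measured

Within the data shown here, in a functional assay on HepG2 cells (Homo sapiens) for inhibition, read by MTT assay, with a stated time of 72 h (on this read-out lower numbers stand for stronger inhibition and higher numbers for weaker inhibition), compound 2 holds the lower of the two numbers, with an 8.0-fold lower number from compound 1 to compound 2 (0.90 log units; beyond the scatter) as the only measured step. Compound 3 brings (bromo in place of chloro on an aromatic carbon), bromo in place of chloro on an aromatic carbon. The measured step, hydrogen in place of chloro, is a different exchange and offers only a loose guide. No step beyond the scatter is therefore expected, and no direction is favoured. The expected step is a 1.1-fold higher number from compound 2 to compound 3 (0.04 log units; within the scatter). For compound 3 the estimated value is 1700 nM, with an expected range from 700 nM to 4000 nM.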

Compound 3, half-maximal inhibitory concentration: 6250 nM
Estimate against measurement, compound 3: 3.7-fold (0.57 log units) below; measured number outside the range, above it.
By their numbers in this assay, from the lowest: compound 2; then compounds 3 and 1 (each within the scatter of the next).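

In this assay, this place on the ring turns out to be sensitive to the identity of the halogen, with a 4.0-fold higher number from compound 2 to compound 3 (0.60 log units; beyond the scatter) for the change from 4-chlorophenyl to 4-bromophenyl. With a 2.0-fold lower number from compound 1 to compound 3 (0.30 log units; within the scatter), the 4-bromophenyl and 3,4-dichlorophenyl groups cannot be told apart in this assay. No measurement available here accounts for the gap between chloro and bromo. As far as these compounds go, what stays open is how fluoro, methoxy or an amine at the same place would compare with chloro.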